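The compounds below may be only part of what the source reports. "The series", "measured", "known", "first", "only" and "open" are said of these compounds alone.

Measured in a functional assay on Rec1 cells (Homo sapiens) for inhibition, read by luminescence and CellTiter-Glo, with a stated time of 72 h; on this read-out higher numbers stand for weaker inhibition and lower numbers for stronger inhibition:
- compound 1 `C=CC(=O)N1CCCC(n2nc(-c3ccc(Oc4ccccc4)cc3)cc2C(=O)O)C1`: 50000 nM
- compound 2 `C=CC(=O)N1CCCC(n2nc(-c3ccc(Oc4ccccc4)cc3)cc2C(=O)OCC)C1`: 13800 nM
- compound 3 `CCOC(=O)c1cc(-c2ccc(Oc3ccccc3)cc2)nn1C1CCCN(C(=O)CCl)C1`: 400 nM

Of these three numbers, compound 2 at 13800 nM is the second highest, with compound 1 higher and compound 3 lower.

Compound 4 `C=CC(=O)N1CCCC(n2nc(-c3ccc(Oc4ccccc4)cc3)cc2CO)C1` has hydroxymethyl in place of ethoxycarbonyl on an aromatic carbon. The closest evidence is a 3.6-fold lower number from compound 1 to compound 2 (0.56 log units; beyond the scatter), a modest step that also alters the group on this aromatic carbon. The large 35-fold lower number from compound 2 to compound 3 (1.54 log units; beyond the scatter) replaces vinyl with chloromethyl on a carbonyl carbon, and compound 4 keeps the vinyl, so that step does not bear on this change. For the measured compounds named here, no measured compound carries hydroxymethyl, which leaves the direction open. In this assay, no step beyond the scatter is expected, though a modest step either way remains possible. The expected change is a 1.4-fold higher number from compound 2 to compound 4 (0.16 log units; within the scatter). For compound 4 the estimated value is 20000 nM, with an expected range of 5000 nM to 60000 nM.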

Compound 4, half-maximal inhibitory concentration: 5400 nM
For compound 4 the middle estimate is 3.7-fold (0.57 log units) above the measured one; the measured number falls inside the stated range.
By their numbers in this assay, from the lowest: compound 3; then compound 4; then compound 2; then compound 1.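

In this assay the ethoxycarbonyl group on this aromatic carbon proves dispensable, since hydroxymethyl in its place gives a 2.6-fold lower number from compound 2 to compound 4 (0.41 log units; beyond the scatter) and so the ester is not required for the activity seen in compound 2. Set against the carboxy group, hydroxymethyl gives a 9.3-fold lower number from compound 1 to compound 4 (0.97 log units; beyond the scatter) and thus has the lowest number of the three compounds that keep the vinyl group, so this position separates all three by more than the scatter. Nothing measured here accounts for that order.

On these data alone, whether an aminomethyl group, a primary carboxamide or a longer chain such as hydroxyethyl on this carbon would lower the number further remains open. Also open, as far as these compounds go, is whether hydroxymethyl gives a similar step when chloromethyl replaces vinyl on the carbonyl carbon.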